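Replacing methylpiperazinyl with imidazolyl on compound 1

The source may report more compounds than this note shows. Statements on the series, on what has been measured and on what is new or still open speak of the compounds shown alone.

Within the data shown here, compound 1 `CC(=O)N1N=C(c2ccc(N3CCN(C)CC3)cc2)CC1c1ccc(N(C)C)cc1` gives -1% in a functional assay on MDA-MB-231 cells (Homo sapiens) for inhibition, read by sulforhodamine B assay, tested at 10 uM (a lower number here means less inhibition, a higher number more inhibition at the concentration tested (going by the name of the read-out)), the lowest of the three numbers measured so far. Compound 2 `CN1CCN(c2ccc(C3=NN(C(=O)c4ccc(C(F)(F)F)cc4)C(c4ccc(N(C)C)cc4)C3)cc2)CC1` gives 55.4% and compound 3 `Cc1ccc(S(=O)(=O)N2N=C(c3ccc(N4CCN(C)CC4)cc3)CC2c2ccc(N(C)C)cc2)cc1` gives 10.7%; the steps of a number 56.4 percentage points higher from compound 1 to compound 2 (beyond the scatter) and a number 11.7 percentage points higher from compound 1 to compound 3 (beyond the scatter) both lie beyond the scatter, as does a number 44.7 percentage points lower from compound 2 to compound 3 (beyond the scatter). All three measured steps alter the group on the ring nitrogen and leave the aryl substituent untouched. Compound 4 `CC(=O)N1N=C(c2ccc(-n3ccnc3)cc2)CC1c1ccc(N(C)C)cc1` keeps the acetyl of compound 1 and changes the aryl side instead: 1H-imidazol-1-yl in place of 4-methylpiperazin-1-yl on an aromatic carbon. Among the measured compounds shown here, no measured step touches this position, so nothing here sets a direction or a size; compound 1 is the only anchor. Any effect is expected to remain within the scatter, with a number 6 percentage points higher from compound 1 to compound 4 (within the scatter). Compound 4 is therefore estimated at 5%, range -15% to 28%.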

Compound 4, a percentage reported as inhibition, at one concentration (the size of the read-out at that concentration, not a potency): 5%
Compound 4: the middle estimate sits on the measured number at the digits printed, and the stated range covers the measured number.
By their numbers in this assay, from the lowest: compounds 1, 4 and 3 (each within the scatter of the next, the first and the last beyond it); then compound 2.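

In this assay, among these compounds, the exchange of 4-methylpiperazin-1-yl for 1H-imidazol-1-yl gives a number 6 percentage points higher from compound 1 to compound 4 (within the scatter) and provides the first reading at this position. With acetyl kept on the ring nitrogen, replacing a six-membered non-aromatic ring with a five-membered aromatic ring on this aromatic carbon leaves the number within the scatter. No supporting data bear on this result.

On these data alone, it remains open whether the same exchange would stay within the scatter with the 4-(trifluoromethyl)benzoyl group of compound 2 on the ring nitrogen. A morpholine or a carboxylic acid at this position is also untested in the compounds shown.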